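Diarylpropane series: cytotoxicity notes toward compound 4

The source may report more compounds than this note shows. Statements on the series, on what has been measured and on what is new or still open speak of the compounds shown alone.

Measured so far in an ADME assay on RAW264.7 cells (Mus musculus) for cytotoxicity, read by MTT assay, with a stated time of 24 h, tested at 10 ug/mL; on this read-out higher numbers stand for a weaker effect at the one concentration tested and lower numbers for a stronger effect:
compound 1 `COc1ccc(CCCc2ccc(OC)c(OC)c2)c(O)c1` — 44.5%
compound 2 `COc1ccc(C(=O)CCc2cccc(OC)c2OC)c(O)c1` — 92.8%
compound 3 `COc1cc(C(=O)CCc2cccc(OC)c2OC)ccc1O` — 90.5%

Compound 1 stands lowest of the three numbers, and its gaps to compound 2 and to compound 3 both lie beyond the scatter, so it shows the strongest effect of the set in this assay. Compound 2 and compound 3 lie within the scatter of each other.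

The next compound is compound 4 `COc1ccc(CCCc2ccc(OC)cc2O)cc1`. Against compound 1 the change is hydrogen in place of methoxy on an aromatic carbon. Among the measured compounds shown here, no measured pair shows such a step, so its size is unknown. With only the value of compound 1 as an anchor, compound 4 is expected near it, with a modest drift toward a weaker effect: the estimated step of a number 10.5 percentage points higher from compound 1 to compound 4 (beyond the scatter) is expected small. Compound 4 is estimated at 55%, expected between 35% and 80%.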

Compound 4, a percentage reported as activity, at one concentration (the size of the read-out at that concentration, not a potency): 73.8%
Estimate against measurement, compound 4: 18.8 percentage points below, within the range that was stated.
By their numbers in this assay, from the lowest: compound 1; then compound 4; then compounds 3 and 2 (each within the scatter of the next).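

In this assay hydrogen in place of methoxy gives a number 29.3 percentage points higher from compound 1 to compound 4 (beyond the scatter) and so a weaker effect at the one concentration tested. This single-place step shows that the read-out of the series responds to the methoxy on this carbon, ortho to a methoxy group and meta to a large group. No measurement shown explains the step.

Going by these compounds, whether an amine or a chlorine on this carbon would read nearer compound 1 or compound 4 stays open. Also open, on these data alone, is whether the same change would give a similar step on the other compounds.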